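Fluoro for Methoxy on a Weakly Cytotoxic Scaffold

A few compounds are considered here, and "the series" means these few. Any claim that something is new, unique, unknown or untested is made for them only; others in the source may bear on it.

Compound 1 `O=C(/C=C\Nc1ccc(F)cc1)c1nc(-c2ccc(C(F)(F)F)cc2)n2ccccc12`: in a functional assay on BT-474 cells (Homo sapiens) for cytotoxicity, read by MTT assay, with a stated time of 48 h (a higher number here means a weaker inhibitor, a lower number a stronger inhibitor), compound 1 gives > 30000 nM, a limit.
Compound 2 `COc1ccc(-c2nc(C(=O)/C=C\Nc3ccc(F)cc3)c3ccccn23)cc1`: in this assay compound 2 gives > 30000 nM, a limit.
Compound 3 `COc1ccc(N/C=C\C(=O)c2nc(-c3ccc(F)cc3)n3ccccc23)cc1`: in this assay compound 3 gives 15700 nM.

Among the compounds with values here, compound 3 holds the only number among the three values shown; the other two are limits (the limit of > 30000 nM in this assay, at which 2 of the 3 values shown sit). Within the data shown here, the one measured step, a step that the two limits leave unreadable from compound 1 to compound 2, cannot be sized and concerns a different ring. Compound 4 `O=C(/C=C\Nc1ccc(F)cc1)c1nc(-c2ccc(F)cc2)n2ccccc12` differs from compound 3 by fluoro in place of methoxy on an aromatic carbon. Among the measured compounds shown here, no measured step bears on this change, so no shift beyond the scatter is expected, with a fair chance the result is again a limit. The estimate for compound 4 in this assay is 25000 nM, from 9000 nM to 70000 nM, a step of a 1.6-fold higher number from compound 3 to compound 4 (0.20 log units; within the scatter) expected.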

Compound 4, half-maximal inhibitory concentration: 16900 nM
Compound 4: middle estimate off by 1.5-fold (0.17 log units), on the high side, and the stated range covers the measured number.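

Changing (4-methoxyphenyl)amino to (4-fluorophenyl)amino gives a 1.1-fold higher number from compound 3 to compound 4 (0.03 log units; within the scatter) in this assay, so the two groups cannot be told apart at this place. On the other aromatic ring, compound 4 gives the limits a number to be set against: fluoro in place of methoxy gives an at least 1.7-fold lower number from compound 2 to compound 4 (0.24 log units; that floor lies within the scatter), and fluoro in place of trifluoromethyl gives an at least 1.7-fold lower number from compound 1 to compound 4 (0.24 log units; that floor lies within the scatter). Both steps rest on a limit, so neither shows a real change.

Going by these compounds, whether an amine or a carboxylic acid at either place would move the number beyond the scatter remains open.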